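Two methyl groups in place of chloro and methyl

The compounds below may be only part of what the source reports. "The series", "measured", "known", "first", "only" and "open" are said of these compounds alone.

Compound 2 `Cc1cc(Cl)ccc1-c1cccc(COc2ccc([C@H](CC(=O)O)c3nccn3C)cc2)c1` holds the lowest of the two numbers shown in an assay on CHO cells for agonist activity at Free fatty acid receptor 1 (Homo sapiens), read by luminescence, with a stated time of 20 s, in the presence of a further agent that is not named here (a lower number here means that less compound is needed, a higher number that more compound is needed for the effect), where compound 2 gives 10000 nM. Its nearest neighbour is compound 1 `Cc1ccc(F)cc1-c1cccc(COc2ccc([C@H](CC(=O)O)c3nccn3C)cc2)c1`, which in this assay gives 42000 nM; the step is a 4.2-fold lower number from compound 1 to compound 2 (0.62 log units; beyond the scatter), a modest move that came from swapping one halogenated aryl group for another on the same aromatic carbon. Compound 3 `Cc1cccc(C)c1-c1cccc(COc2ccc([C@H](CC(=O)O)c3nccn3C)cc2)c1` carries the change (2,6-dimethylphenyl in place of 4-chloro-2-methylphenyl on an aromatic carbon). Going by the values given here, the only measured step that bears on this exchange is the one from compound 1 to compound 2, which shows that reshaping the substituents on this distal ring can shift the number by a modest amount in either direction, and no measured pair reports what removing the chlorine altogether does. The expectation for compound 3 in this assay is therefore a small step, likely toward a lower number but possibly none beyond the scatter, estimated as a 2.0-fold lower number from compound 2 to compound 3 (0.30 log units; within the scatter). Compound 3 is estimated to give 5000 nM in this assay, within a range of 1500 nM to 25000 nM.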

Compound 3, half-maximal effective concentration: 29000 nM
Beside the measured number, compound 3's estimate is 5.8-fold (0.76 log units) below it, outside the stated range (above it).
By their numbers in this assay, from the lowest: compound 2; then compounds 3 and 1 (each within the scatter of the next).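

In this assay, putting 2,6-dimethylphenyl in place of 4-chloro-2-methylphenyl on this aromatic carbon, meta to a large group, gives a 2.9-fold higher number from compound 2 to compound 3 (0.46 log units; beyond the scatter) and so moves the number up, the opposite direction to the step that led to compound 2. Against the other aryl group, the same exchange gives a 1.4-fold lower number from compound 1 to compound 3 (0.16 log units; within the scatter) and leaves 2,6-dimethylphenyl and 5-fluoro-2-methylphenyl indistinguishable here, so among these three compounds only compound 2, with 4-chloro-2-methylphenyl, stands apart, with the lowest number. Nothing among the data shown accounts for this difference between the three aryl groups.

The compounds shown leave open whether the lower number of compound 2 goes with the chlorine itself or with any group at that place on the ring, a question that a methoxy or a nitrile group in place of that chlorine would address. They also leave open how a plain phenyl group, carrying neither methyl nor halogen, would compare with these three aryl groups on the same aromatic carbon.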